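Methoxy removal on the pyrazole aryl ring of compound 1

This account rests on a few compounds, and the source may have more. Where it says the series, first, only, none or still open, it means among the compounds named here.

In a functional assay on Hs-578T cells (Homo sapiens) for cytotoxicity, read by sulforhodamine B assay, with a stated time of 48 h, tested at 1 uM (on this read-out lower numbers stand for a stronger effect and higher numbers for a weaker effect at the one concentration tested), compound 1 `COc1cc(-c2cc(/C=C/C(=O)c3ccc(N)cc3)[nH]n2)cc(OC)c1OC` gives 87%. Compound 2 `COc1ccc(C(=O)/C=C/c2cc(-c3cc(OC)c(OC)c(OC)c3)n[nH]2)cc1OC` gives 91%, and compound 3 `COc1ccc(C(=O)/C=C/c2cc(-c3cc(OC)c(OC)c(OC)c3)n[nH]2)cc1` gives 96%; the steps of a number 4 percentage points higher from compound 1 to compound 2 (within the scatter) and a number 9 percentage points higher from compound 1 to compound 3 (within the scatter) keep all three within the usual scatter. Compound 4 `COc1ccc(-c2cc(/C=C/C(=O)c3ccc(N)cc3)[nH]n2)cc1OC` is not yet measured. It differs from compound 1 by hydrogen in place of methoxy on an aromatic carbon. The same kind of change is already measured as hydrogen in place of methoxy on an aromatic carbon, where the step is a number 5 percentage points higher from compound 2 to compound 3 (within the scatter); around the place in compound 1 the carbon is additionally meta to a methoxy group. The two cores differ by 4-aminophenyl in place of 3,4-dimethoxyphenyl on a carbonyl carbon. Because a number 5 percentage points higher from compound 2 to compound 3 (within the scatter) stays within the scatter, the step of a number 5 percentage points higher from compound 1 to compound 4 (within the scatter) is expected to be of similar, small size. Compound 4 is estimated at 92%, between 80% and 102%.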

Compound 4, a percentage reported as activity, at one concentration (the size of the read-out at that concentration, not a potency): 96%
For compound 4 the middle estimate is 4 percentage points below the measured one, within the range that was stated.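

Hydrogen in place of methoxy on an aromatic carbon gives, in this assay, a number 9 percentage points higher from compound 1 to compound 4 (within the scatter). Set beside the earlier case, the change carries from one core to the other with no difference in step size that can be told apart: the same change on two cores in this assay, a number 5 percentage points higher (within the scatter) from compound 2 to compound 3 and a number 9 percentage points higher (within the scatter) from compound 1 to compound 4, 4 percentage points apart, within the scatter of two such steps. This does not show that the change has a real effect on either core, as both steps lie within the scatter, nor does it show that the two steps would stay alike on a core beyond these two.

Open, on these data alone, is whether a hydroxyl or a carboxylic acid in place of this methoxy would move the read-out beyond the scatter. As far as these compounds go, how the effect changes with concentration also stays open, with each compound read at a single concentration.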